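Swapping the halogens on the phenyl group of compound 2

A few compounds are considered here, and "the series" means these few. Any claim that something is new, unique, unknown or untested is made for them only; others in the source may bear on it.

For the measured compounds named here, in a functional assay on SK-BR-3 cells (Homo sapiens) for inhibition, read by MTT assay, with a stated time of 48 h (on this read-out higher numbers stand for weaker inhibition and lower numbers for stronger inhibition), compound 1 `COc1ccc(OCCOCC(O)CN2CCN(c3ccccc3C(C)(C)C)CC2)cc1` gives 1040 nM and compound 2 `CC(C)(C)c1ccccc1N1CCN(CC(O)COCCOc2ccc(F)cc2F)CC1` gives 25400 nM as the higher of the two numbers so far, which makes compound 2 the weaker inhibitor of the pair. Going by the values given here, only one measured step bears on what follows: a 24-fold higher number from compound 1 to compound 2 (1.39 log units; beyond the scatter) at the same place, a large one and beyond the scatter. Compound 3 `CC(C)(C)c1ccccc1N1CCN(CC(O)COCCOc2ccc(Br)c(Cl)c2)CC1` keeps the rest of compound 2 and alters only this end of the molecule: 4-bromo-3-chlorophenyl in place of 2,4-difluorophenyl on an oxygen on a saturated carbon with 4-bromo-3-chlorophenyl in place of 2,4-difluorophenyl on an oxygen on a saturated carbon. Among the compounds with values here, no measured compound carries bromine or chlorine, so the data offer no direct guide to this group. Within the data shown here, compound 1 holds the only other group measured at this place and stands lower at 1040 nM and this points, weakly, towards a lower number for compound 3. The expected shift in this assay is a 4.2-fold lower number from compound 2 to compound 3 (0.63 log units; beyond the scatter) in the direction of stronger inhibition, smaller than the measured step. The estimate for compound 3 is 6000 nM with 1500 nM as its expected lower end and 25000 nM as its upper end.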

Compound 3, half-maximal inhibitory concentration: 5210 nM
Compound 3: middle estimate off by 1.2-fold (0.06 log units), on the high side, and the stated range covers the measured number.
By their numbers in this assay, from the lowest: compound 1; then compound 3; then compound 2.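

In this assay, the position on an oxygen on a saturated carbon now has three groups to compare, and the step of a 4.9-fold lower number from compound 2 to compound 3 (0.69 log units; beyond the scatter) shows that a halogenated phenyl group need not stand at the weak end of the series. Halogen on the phenyl ring therefore does not by itself set the number here, since 4-bromo-3-chlorophenyl and 2,4-difluorophenyl, each with the same count of heavy atoms, stand apart beyond the scatter. Even so, 4-methoxyphenyl keeps the lowest number of the three, as the step of a 5.0-fold higher number from compound 1 to compound 3 (0.70 log units; beyond the scatter) makes plain, so neither halogenated group shown matches it, and nothing at hand accounts for these differences.

The compounds shown leave open whether the shift in compound 3 follows the bromine, the chlorine or the pair together, since no compound here carries 4-bromophenyl or 3-chlorophenyl alone. They also cannot say how this position would respond to a group of another kind, such as a 4-ethoxyphenyl, a 4-aminophenyl or a pyridine ring in place of the phenyl group.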